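Amide to sulfonamide on a benzimidazole chalcone series

The source may report more compounds than this note shows. Statements on the series, on what has been measured and on what is new or still open speak of the compounds shown alone.

Measured compounds in a functional assay on MCF7 cells (Homo sapiens) for antiproliferative activity, read by MTT assay, with a stated time of 48 h; on this read-out lower numbers stand for stronger inhibition and higher numbers for weaker inhibition:
Compound 1 `O=C(Nc1cccc(/C=C/C(=O)c2nc3ccccc3[nH]2)c1)c1ccccc1` gives 11200 nM.
Compound 2 `Cc1ccccc1C(=O)Nc1cccc(/C=C/C(=O)c2nc3ccccc3[nH]2)c1` gives 5870 nM.
Compound 3 `O=C(Nc1cccc(/C=C/C(=O)c2nc3ccccc3[nH]2)c1)c1cccc(C(F)(F)F)c1` gives 21500 nM.

Compound 2 stands at the lowest of the three numbers in this assay; its nearest neighbour is compound 1, with a 1.9-fold lower number from compound 1 to compound 2 (0.28 log units; within the scatter), a gap within the scatter, and its furthest is compound 3, with a 3.7-fold higher number from compound 2 to compound 3 (0.56 log units; beyond the scatter). The step of a 1.9-fold higher number from compound 1 to compound 3 (0.28 log units; within the scatter) is itself within the scatter.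

Compound 4 `O=C(/C=C/c1cccc(NS(=O)(=O)c2cccc(Cl)c2)c1)c1nc2ccccc2[nH]1` differs from compound 2 in one place: (3-chlorophenyl)sulfonyl in place of (2-methylphenyl)carbonyl on a nitrogen on an aromatic ring. For the measured compounds named here, no measured step exchanges the carbonyl for a sulfonyl on that nitrogen, so nothing here speaks directly to that change. Going by the values given here, the only step that bears on it at all is the exchange of 2-methylphenyl for a 3-substituted phenyl, a 3.7-fold higher number from compound 2 to compound 3 (0.56 log units; beyond the scatter), a modest rise. Compound 4 is therefore expected to give a somewhat higher number than compound 2, by about a 2.0-fold higher number from compound 2 to compound 4 (0.31 log units; beyond the scatter). The estimate for compound 4 in this assay is 12000 nM, with a range from 4000 nM to 40000 nM.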

Compound 4, half-maximal inhibitory concentration: 4160 nM
For compound 4 the middle estimate is 2.9-fold (0.46 log units) above the measured one; the range from low to high includes it.
By their numbers in this assay, from the lowest: compounds 4, 2, 1 and 3 (each within the scatter of the next, the first and the last beyond it).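

For the compounds shown here, at the nitrogen on an aromatic ring, the earlier compounds varied only the aryl group on the carbonyl, whereas compound 4 replaces the carbonyl link as well, and in this assay this gives a 1.4-fold lower number from compound 2 to compound 4 (0.15 log units; within the scatter) against the best of the amides, so the two cannot be told apart. Against the unsubstituted benzoyl group the same kind of exchange gives a 2.7-fold lower number from compound 1 to compound 4 (0.43 log units; beyond the scatter), a modest gain that shows a sulfonyl-linked aryl group is accepted at this position. Nothing available explains this result.

On these data alone, each of these steps changes the link and the ring substituent together, so the share of each remains open. A 3-chlorobenzoyl or a plain phenylsulfonyl group on that nitrogen would separate the two, and a methylsulfonyl group would test whether the aryl ring is needed at all.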